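Swapping a tert-Butyl Ester for an Octyl Ester

The source may report more compounds than this note shows. Statements on the series, on what has been measured and on what is new or still open speak of the compounds shown alone.

Compound 1 `CCCCCCCCCCOC(=O)CC(=O)Nc1c(C(C)C)cccc1C(C)C` and compound 2 `CC(C)c1cccc(C(C)C)c1NC(=O)CC(=O)OC(C)(C)C` share one core and differ only in the ester group. In an assay on microsomes from intestine for inhibition of acyl-CoA:cholesterol acyltransferase (Oryctolagus cuniculus) (a lower number here means a stronger inhibitor, a higher number a weaker inhibitor), compound 1 gives 53 nM, while compound 2 gives 130 nM. Compound 2 therefore holds the higher of the two numbers, and its gap to compound 1 lies beyond the scatter of the measurement. Compound 3 `CCCCCCCCOC(=O)CC(=O)Nc1c(C(C)C)cccc1C(C)C` has not yet been tested in this assay. It differs from compound 2 in a single place: octyl in place of tert-butyl on an oxygen next to a carbonyl group. Going by the values given here, no measured pair shows this exact change, so the size of the step rests on analogy. Compound 1, carrying a decyl chain on that same oxygen, gives 53 nM, and octyl stands closer to decyl than to tert-butyl. The step from compound 2 to compound 3 is therefore expected to be a decrease of about a 2.0-fold lower number from compound 2 to compound 3 (0.30 log units; within the scatter), modestly beyond the scatter. Compound 3 is estimated to give roughly 65 nM in this assay, most likely between 25 nM and 170 nM.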

Compound 3, half-maximal inhibitory concentration: 260 nM
The estimate for compound 3 lay 4.0-fold (0.60 log units) below the measured number, outside the stated range (above it).
By their numbers in this assay, from the lowest: compound 1; then compounds 2 and 3 (each within the scatter of the next).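

In this assay, the exchange of tert-butyl for octyl on the oxygen next to the carbonyl group gives a 2.0-fold higher number from compound 2 to compound 3 (0.30 log units; within the scatter), so this branched group and this straight chain cannot be told apart here. The two straight chains can be told apart: the change from decyl to octyl gives a 4.9-fold higher number from compound 1 to compound 3 (0.69 log units; beyond the scatter), which shows that a difference confined to the far end of the chain registers at this position even though the larger exchange of tert-butyl for octyl does not. No measurement at hand accounts for either step.

The compounds shown leave open how a shorter straight chain such as butyl or a longer one such as dodecyl would behave at this position. They also leave open whether a branched group with more carbons than tert-butyl, or a chain ending in an amine or a carboxylic acid, would be tolerated there.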